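Methyl on the Ring: Notes Toward Compound 4

The source may report more compounds than this note shows. Statements on the series, on what has been measured and on what is new or still open speak of the compounds shown alone.

Three members of this series have been run in a functional assay on MCF7 cells (Homo sapiens) for cytotoxicity, read by MTT assay, with a stated time of 72 h, tested at 10 uM; on this read-out higher numbers stand for more inhibition of growth at the one concentration tested and lower numbers for less inhibition of growth. Compound 1 `N/C(=N\NC(=S)N1CCCCCC1)c1ccccn1` gives 62.2%. Compound 2 `Cc1ccnc(/C(N)=N/NC(=S)N2CCSCC2)c1` gives 62.5%, and compound 3 `N/C(=N\NC(=S)N1CCSCC1)c1ccccn1` gives 54.3%. Compounds 3 and 2 differ in one place: methyl in place of hydrogen on an aromatic carbon. Across that pair the step is a number 8.2 percentage points higher from compound 3 to compound 2 (within the scatter). Compound 1 and compound 2 lie within the scatter of each other, as do compound 1 and compound 3; the difference between the core of compound 1 and the core of compound 3 is not broken down here.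

Compound 4 `Cc1cccc(/C(N)=N/NC(=S)N2CCCCCC2)n1` has not yet been measured in this assay. It differs from compound 1 as follows: methyl in place of hydrogen on an aromatic carbon. This is the same kind of change as that from compound 3 to compound 2, not the same change: in compound 4 the methyl stands next to the ring nitrogen, whereas in compound 2 it stands opposite the ring nitrogen; in both cases it is meta to a large group. Going by the values given here, only one such step has been measured, and it lies within the scatter, so any expectation for compound 4 rests on that one step and on the value of compound 1. The step from compound 1 to compound 4 in this assay is expected to be a number 3.8 percentage points higher from compound 1 to compound 4 (within the scatter), because the measured step of a number 8.2 percentage points higher from compound 3 to compound 2 (within the scatter) was small. Compound 4 is therefore estimated at 66%, with a range from 52% to 79%.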

Compound 4, percent growth inhibition at one concentration: 21.5%
Compound 4: the middle estimate sits 44.5 percentage points above what was measured; the measured number lies below the stated range.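

In this assay, methyl in place of hydrogen on an aromatic carbon gives a number 40.7 percentage points lower from compound 1 to compound 4 (beyond the scatter), set against a number 8.2 percentage points higher from compound 3 to compound 2 (within the scatter) for the earlier pair, so in this series the change does not carry from one core to another as a fixed step: the same change on two cores in this assay, a number 8.2 percentage points higher (within the scatter) from compound 3 to compound 2 and a number 40.7 percentage points lower (beyond the scatter) from compound 1 to compound 4, 48.9 percentage points apart, beyond the scatter of two such steps

The two pairs differ in more than the core, since in compound 4 the methyl stands next to the ring nitrogen while in compound 2 it stands at another place on the ring, and these compounds cannot separate the part played by the core from the part played by the place of the methyl. Going by these compounds alone, with only two such steps, the notes support no general rule for this change, and the data give no reason for the drop from compound 1 to compound 4.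

The compounds shown leave open how the core of compound 3 responds to a methyl next to the ring nitrogen, which would hold the place fixed and vary only the core. They also leave open whether an ethyl, a methoxy or a chlorine at that place on the core of compound 1 would follow the methyl of compound 4 or stay with the unsubstituted compound 1.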